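The source may report more compounds than this note shows. Statements on the series, on what has been measured and on what is new or still open speak of the compounds shown alone.

Measured so far in an ADME assay on HEp-2 cells (Homo sapiens) for cytotoxicity; a higher number here means that more compound is tolerated, a lower number that less compound is tolerated:
- compound 1 `CC(C)CCn1c(CN2C(=O)N(CC(=O)O)S(=O)(=O)c3ccccc32)nc2ccccc21` gives 60200 nM
- compound 2 `CC1(C)C(=O)N(Cc2nc3ccccc3n2CCCCF)c2ccccc2S1(=O)=O` gives 158000 nM

Compound 1 holds the lower of the two numbers, and the gap up to compound 2 lies beyond the scatter. Against compound 1, compound 3 `CC(C)CCn1c(CN2C(=O)N(CC(=O)OC(C)(C)C)S(=O)(=O)c3ccccc32)nc2ccccc21` shows tert-butyl in place of hydrogen on an oxygen next to a carbonyl group as its one change, tert-butyl in place of hydrogen on an oxygen next to a carbonyl group. Among the measured compounds shown here, no measured pair differs in one place, so no measured step guides the expectation. In this assay the step of a 2.0-fold lower number from compound 1 to compound 3 (0.30 log units; within the scatter) is expected to be a moderate fall, beyond the scatter. Compound 3 is estimated at 30000 nM, with an expected range from 9000 nM to 90000 nM.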

Compound 3, half-maximal cytotoxic concentration: 18400 nM
Compound 3: the middle estimate sits 1.6-fold (0.21 log units) above what was measured; low and high end bracket the measured number.
By their numbers in this assay, from the lowest: compound 3; then compound 1; then compound 2.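

In this assay, among the compounds shown here, this oxygen gives the only readable step: tert-butyl in place of hydrogen on an oxygen next to a carbonyl group yields a 3.3-fold lower number from compound 1 to compound 3 (0.51 log units; beyond the scatter), so less compound is tolerated with tert-butoxycarbonyl than with carboxy. The position therefore responds to this change beyond the scatter. Nothing available accounts for the shift. Open, from the compounds shown here alone, is whether the fall depends on the size of the group: a methyl ester, an ethyl ester or a primary amide in place of the carboxylic acid would test this.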